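Vero cytotoxicity notes on a shared-core series, compounds 1 to 4

The source may report more compounds than this note shows. Statements on the series, on what has been measured and on what is new or still open speak of the compounds shown alone.

Measured so far in an ADME assay on Vero cells (Chlorocebus sabaeus) for cytotoxicity, read by MTT assay, with a stated time of 72 h; a higher number here means that more compound is tolerated, a lower number that less compound is tolerated:
compound 1 `C[C@]1(CN2CCc3oc(-c4ccc(F)c(F)c4)nc3C2)Cn2cc([N+](=O)[O-])nc2O1`, "not determined" (no result reported)
compound 2 `C[C@]1(CN2CCc3nc(-c4ccc(F)cc4)sc3C2)Cn2cc([N+](=O)[O-])nc2O1`, > 32 ug/mL
compound 3 `C[C@]1(CN2CCc3nc(N4CCCCC4)ccc3C2)Cn2cc([N+](=O)[O-])nc2O1`, "not determined" (no result reported)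
compound 4 `C[C@]1(CN2CCc3nc(-c4ccc(C(F)(F)F)cc4)ccc3C2)Cn2cc([N+](=O)[O-])nc2O1`, to be measured

Compound 2 gives only a limit of this assay, > 32 ug/mL. Compound 3 has no single number in this assay, and nothing else in the set gives one either: of the three entries, one is a limit and two carry no result. Within the data shown here, compound 3 therefore cannot be placed against any neighbour by a measured step, and no step between measured compounds exists.

Compound 4 carries 4-(trifluoromethyl)phenyl in place of piperidin-1-yl on an aromatic carbon. Among the measured compounds shown here, with no measured step to lean on, the expectation in this assay is no change beyond the usual scatter, since the one reported entry, compound 2 at the limit of > 32 ug/mL in this assay, at which 1 of the 3 values shown sits, sits at the limit and gives no direction. Compound 4 is expected to show 32 ug/mL, in a range from 10 ug/mL to 64 ug/mL, most likely again reported only as a limit.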

Compound 4, half-maximal cytotoxic concentration: > 32 ug/mL
Compound 4: only a limit was reported; the forecaster's own chance of this, stated with the estimate: 65%; the middle value sits exactly at the limit.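

Compound 4 gives > 32 ug/mL in this assay, which is a limit and not a number. Compound 3 has no single number, so no step can be read between compound 3 and compound 4. The compounds shown leave open what concentration of any compound in the series is no longer tolerated: the limit of > 32 ug/mL in this assay, at which 2 of the 4 values shown sit.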